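A Small Swap on a Weak Antiproliferative Amide

The compounds below may be only part of what the source reports. "The series", "measured", "known", "first", "only" and "open" are said of these compounds alone.

In a functional assay on HeLa cells (Homo sapiens) for antiproliferative activity, read by MTT assay, with a stated time of 72 h (a lower number here means a stronger inhibitor, a higher number a weaker inhibitor), compound 1 `CC(C)=CC(=O)Nc1cccc(Oc2nc(Nc3ccn(C)n3)nc3c2CSCC3)c1` gives > 50000 nM, which is a limit and not a number. Within the data shown here, compound 2 `CCC/C=C/C(=O)Nc1cccc(Oc2nc(Nc3cccc(OC)c3)nc3c2CSCC3)c1` gives 33800 nM, the only true number so far. Compound 3 `COc1cccc(Nc2nc3c(c(Oc4cccc(NC(=O)C=C(C)C)c4)n2)CSCC3)c1` keeps the rest of compound 2 but has 2-methylprop-1-en-1-yl in place of pent-1-en-1-yl on a carbonyl carbon. Among the measured compounds shown here, no measured pair shows what this swap does. Compound 1 also carries 2-methylprop-1-en-1-yl, and its result is the limit > 50000 nM. The expected step of a 1.1-fold higher number from compound 2 to compound 3 (0.05 log units; within the scatter) is small, slightly toward weaker and within the usual scatter. Compound 3 is expected to give about 38000 nM, with an estimated range of 18000 nM to 50000 nM.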

Compound 3, half-maximal inhibitory concentration: 19100 nM
For compound 3 the middle estimate is 2.0-fold (0.30 log units) above the measured one; the range from low to high includes it.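

On the carbonyl carbon, 2-methylprop-1-en-1-yl in place of pent-1-en-1-yl now has a measured pair, and in this assay the two chains cannot be told apart (a 1.8-fold lower number from compound 2 to compound 3 (0.25 log units; within the scatter)). A clearer step comes with 3-methoxyphenyl in place of 1-methyl-1H-pyrazol-3-yl on a nitrogen on an aromatic ring (an at least 2.6-fold lower number from compound 1 to compound 3 (0.41 log units; beyond the scatter)). That step gives only a minimum size, since compound 1 stands at a limit and not a number: the limit of > 50000 nM in this assay, at which 1 of the 3 values shown sits.

Going by these compounds, whether an amine or a carboxylic acid in the chain on that carbonyl carbon would change the result stays open. So does the true value of compound 1.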